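Hydroxyphenyl for chlorophenyl on a shared core: an expectation

The source may hold more compounds than are shown below. What is called first, only, known or untested is meant among the compounds shown, and "the series" means these compounds.

Compound 1 `Cc1cccc(NC(=O)CSC(=S)N[C@H]2CCOC2=O)c1C` gives 42200 nM in a functional assay on SMMC-7721 cells (Homo sapiens) for cytotoxicity, read by MTT assay, with a stated time of 72 h; on this read-out lower numbers stand for stronger inhibition and higher numbers for weaker inhibition.
Compound 2 `O=C(CSC(=S)N[C@H]1CCOC1=O)Nc1cccc(Cl)c1` gives > 128000 nM in this assay, a limit of the assay.
Compound 3 `O=C(CSC(=S)N[C@H]1CCOC1=O)Nc1cccc([N+](=O)[O-])c1` gives > 128000 nM in this assay, a limit of the assay.

Compound 2 stands at the limit of this assay rather than at a number, which is the limit of > 128000 nM in this assay, at which 2 of the 3 values shown sit. Within the data shown here, the single measured step on this core, a step that the two limits leave unreadable from compound 2 to compound 3, is left unreadable by the two limits, so no step size on the aryl group is available. Compound 4 `O=C(CSC(=S)N[C@H]1CCOC1=O)Nc1ccc(O)cc1` carries 4-hydroxyphenyl in place of 3-chlorophenyl on an amide-type nitrogen. Among the measured compounds shown here, no measured step bears on a hydroxyl or on a 4-substituted aryl, and the only compound with a numerical value, compound 1, differs from compound 2 by a group not repeated in compound 4. The expectation for compound 4 therefore rests on the position of compound 2 at the limit, and the outcome is expected to be a further limit or a weak number, giving an expected step of an at least 1.1-fold lower number from compound 2 to compound 4 (0.06 log units; that floor lies within the scatter). Compound 4 is estimated at 110000 nM, within 30000 nM to 300000 nM.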

Compound 4, half-maximal inhibitory concentration: > 128000 nM
Compound 4: no number, only a limit; the forecaster's own chance of this, stated with the estimate: 65%; middle value at least 1.1-fold (0.06 log units) away from the limit.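

Compound 2 and compound 4 both sit at a limit of this assay and not at a number, so no step between them can be read: the limit of > 128000 nM in this assay, at which 3 of the 4 values shown sit.

The compounds shown leave open how far changing the aryl group on the shared core alters the read-out, as only compound 1 carries a number.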